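Same Chlorophenyl Shift on a Second Core

The source may report more compounds than this note shows. Statements on the series, on what has been measured and on what is new or still open speak of the compounds shown alone.

Measured compounds:
compound 1, `Oc1ccc(-c2cc(-c3cccs3)nc(-c3ccccc3Cl)c2)cc1`, 5870 nM
compound 2, `Oc1ccc(-c2cc(-c3ccc(Cl)cc3)nc(-c3cccs3)c2)cc1`, 6450 nM
compound 3, `Oc1cccc(-c2cc(-c3cccnc3)nc(-c3ccccc3Cl)c2)c1`, "not determined" (no result reported)

In a functional assay on T47D cells (Homo sapiens) for cytotoxicity, read by CCK-8 assay and cell counting, with a stated time of 2 days (a lower number here means a stronger inhibitor, a higher number a weaker inhibitor), compound 1 gives 5870 nM, and compound 2 gives 6450 nM. The two are joined by a single change, (4-chlorophenyl in place of 2-chlorophenyl on an aromatic carbon), and the step it made is a 1.1-fold higher number from compound 1 to compound 2 (0.04 log units; within the scatter), so the two values cannot be told apart.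

Compound 3 is built on a different core; how that core differs from the core of compound 1 is not broken down here. For compound 3 the outcome in this assay is "not determined" (no result reported), so no number stands behind it.

Compound 4, `Oc1cccc(-c2cc(-c3ccc(Cl)cc3)nc(-c3cccnc3)c2)c1`, has not yet been measured. It differs from compound 3 by 4-chlorophenyl in place of 2-chlorophenyl on an aromatic carbon. Within the data shown here, this is the same kind of change as the one from compound 1 to compound 2, though the surroundings are not identical: here the place is meta to a 3-hydroxyphenyl group and meta to a pyridin-3-yl group, whereas in the earlier pair it was meta to a 4-hydroxyphenyl group and meta to a thiophen-2-yl group.

Compound 3 has no number, so the expectation for compound 4 cannot rest on a step from it. It rests instead on compound 1 at 5870 nM and compound 2 at 6450 nM, which sit together, and on the earlier step of a 1.1-fold higher number from compound 1 to compound 2 (0.04 log units; within the scatter), which suggests the change itself does little. As far as these compounds go, compound 4 is therefore expected to fall near 6500 nM, estimated between 1500 nM and 25000 nM, with the wide range reflecting that the second core is untested.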

Compound 4, half-maximal inhibitory concentration: 18100 nM
The estimate for compound 4 lay 2.8-fold (0.44 log units) below the measured number; low and high end bracket the measured number.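

In this assay, among these compounds, compound 4 gives 18100 nM but compound 3 has no number, so no step between them can be read. The compounds shown leave open whether 4-chlorophenyl in place of 2-chlorophenyl does as little on the core of compound 3 as on the core of compound 1. Nothing shown here offers an explanation for the value of compound 4.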